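Halogen swap on the benzyl group of a bromo-substituted oxindole thiosemicarbazone

This account rests on a few compounds, and the source may have more. Where it says the series, first, only, none or still open, it means among the compounds named here.

Three compounds from one series were measured in a functional assay on MOLT-4 cells (Homo sapiens), with a stated time of 72 h; on this read-out lower numbers stand for stronger inhibition and higher numbers for weaker inhibition. Compound 1 `O=C1/C(=N\NC(=S)Nc2ccc(Cl)cc2)c2cc(Cl)ccc2N1Cc1ccc(Cl)cc1` gives 58000 nM, and compound 2 `O=C1/C(=N\NC(=S)Nc2ccc(Cl)cc2)c2cc(Cl)ccc2N1Cc1ccc(F)cc1` gives 48000 nM. Between them lies one change, (chloro in place of fluoro on an aromatic carbon), and the step it made is a 1.2-fold higher number from compound 2 to compound 1 (0.08 log units; within the scatter). Compound 3 `Cc1ccc(NC(=S)N/N=C2\C(=O)N(Cc3ccc(F)cc3)c3ccc(Br)cc32)cc1` gives 57000 nM in this assay ; how its core differs from that of compound 2 is not broken down here. Compound 4 `Cc1ccc(NC(=S)N/N=C2\C(=O)N(Cc3ccc(Cl)cc3)c3ccc(Br)cc32)cc1` has not yet been measured. It differs from compound 3 by chloro in place of fluoro on an aromatic carbon, the same change as that from compound 2 to compound 1. Because the earlier step was a 1.2-fold higher number from compound 2 to compound 1 (0.08 log units; within the scatter), compound 4 is expected to move by about a 1.1-fold higher number from compound 3 to compound 4 (0.06 log units; within the scatter) in this assay . Compound 4 is therefore estimated at 65000 nM, between 38000 nM and 110000 nM.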

Compound 4, half-maximal inhibitory concentration: 288000 nM
Compound 4: the middle estimate sits 4.4-fold (0.65 log units) below what was measured; the whole stated range lies below it.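

In this assay, chloro in place of fluoro on the benzyl group gives a 5.1-fold higher number from compound 3 to compound 4 (0.70 log units; beyond the scatter), a weakening of inhibition on this core, whereas the same change on the core of compound 2 stays within the scatter. The change therefore did not carry over at the same size from one core to the other: the same change on two cores in this assay, a 1.2-fold higher number (0.08 log units; within the scatter) from compound 2 to compound 1 and a 5.1-fold higher number (0.70 log units; beyond the scatter) from compound 3 to compound 4, 4.2-fold (0.62 log units) apart, beyond the scatter of two such steps. Among the compounds shown here, this rests on only two matched pairs, so it shows that the size of the step depends on the core, but not which feature of the cores is responsible, nor why.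

On these data alone, it remains open whether a methoxy group or a carboxylic acid in place of the halogen on the benzyl group would also behave differently on the two cores. As far as these compounds go, it also remains open which of the two steps a further core would resemble.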